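Carbamate Swap: Chloro for Fluoro on Compound 3

This account rests on a few compounds, and the source may have more. Where it says the series, first, only, none or still open, it means among the compounds named here.

In a functional assay on PANC-1 cells (Homo sapiens) for inhibition, read by MTT assay, with a stated time of 24 h, tested at 10 uM (a lower number here means less inhibition, a higher number more inhibition at the concentration tested (going by the name of the read-out)), compound 3 `CC(C)=CCC1Cc2c(OC(=O)Nc3ccc(F)c(F)c3)cc(=O)n(CCCO)c2CC1(C)C` gives 76.7%, the highest of the three numbers, though compound 2 `COc1ccccc1NC(=O)Oc1cc(=O)n(CCCO)c2c1CC(CC=C(C)C)C(C)(C)C2` with 71.1% lies within the scatter of it, while compound 1 `CC(C)=CCC1Cc2c(OCc3ccccc3)cc(=O)n(CCCO)c2CC1(C)C` gives -0.3%. The two large steps, a number 77 percentage points higher from compound 1 to compound 3 (beyond the scatter) and a number 71.4 percentage points higher from compound 1 to compound 2 (beyond the scatter), came from replacing benzyl with a carbamoyl group; the step of a number 5.6 percentage points higher from compound 2 to compound 3 (within the scatter), a change of the aryl group on the amide-type nitrogen, stayed within the scatter. Compound 4 `CC(C)=CCC1Cc2c(OC(=O)Nc3ccc(F)c(Cl)c3)cc(=O)n(CCCO)c2CC1(C)C` differs from compound 3 by chloro in place of fluoro on an aromatic carbon. That aryl-ring step is the one that bears on it, and it was small, so no change beyond the scatter is expected: the estimated step is a number 0.7 percentage points lower from compound 3 to compound 4 (within the scatter). Compound 4 is expected to give 76%, between 62% and 88%.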

Compound 4, a percentage reported as inhibition, at one concentration (the size of the read-out at that concentration, not a potency): 79.8%
Beside the measured number, compound 4's estimate is 3.8 percentage points below it; measured number inside the range.
By their numbers in this assay, from the lowest: compound 1; then compounds 2, 3 and 4 (each within the scatter of the next).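

In this assay, chloro in place of fluoro on an aromatic carbon ortho to a fluoro group gives a step that can't be told from scatter (a number 3.1 percentage points higher from compound 3 to compound 4 (within the scatter)), so the number is level with either halogen at this position. The 3-chloro-4-fluorophenyl group also stays within the scatter of 2-methoxyphenyl (a number 8.7 percentage points higher from compound 2 to compound 4 (within the scatter)), while replacing benzyl with this carbamoyl gives a large step (a number 80.1 percentage points higher from compound 1 to compound 4 (beyond the scatter)). No measurement shown explains these steps.
Going by these compounds, it remains open whether trifluoromethyl or an amine at this aromatic carbon would retain the inhibition seen with chloro and fluoro.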